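Swapping chloro for methyl on a thiosemicarbazide series

The compounds below may be only part of what the source reports. "The series", "measured", "known", "first", "only" and "open" are said of these compounds alone.

Measured so far, in a functional assay on CNE-2 cells (Homo sapiens) for cytotoxicity, read by MTT assay, with a stated time of 72 h; on this read-out higher numbers stand for weaker inhibition and lower numbers for stronger inhibition:
- compound 1 `COc1cc2ncnc(NNC(=S)NC(=O)c3ccc(C(F)(F)F)cc3)c2cc1OC` gives 16500 nM
- compound 2 `COc1cc2ncnc(NNC(=S)NC(=O)c3ccccc3C)c2cc1OC` gives 10500 nM
- compound 3 `COc1cc2ncnc(NNC(=S)NC(=O)c3ccc(C)cc3)c2cc1OC` gives 33300 nM

Compound 3 gives the highest number of the three. Its nearest neighbour is compound 1, and that gap, a 2.0-fold higher number from compound 1 to compound 3 (0.30 log units; within the scatter), stays within the scatter. Its distance from compound 2, a 3.2-fold higher number from compound 2 to compound 3 (0.50 log units; beyond the scatter), lies beyond the scatter, so on these numbers compound 3 and compound 2 are told apart, while compound 3 and compound 1 are not.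

Compound 4 `COc1cc2ncnc(NNC(=S)NC(=O)c3ccc(Cl)cc3)c2cc1OC` is the next member. It differs from compound 3 by chloro in place of methyl on an aromatic carbon. For the measured compounds named here, only one measured step touches that same aromatic carbon: a 2.0-fold higher number from compound 1 to compound 3 (0.30 log units; within the scatter), which swapped trifluoromethyl for methyl and stayed within the scatter. The step of a 1.6-fold lower number from compound 1 to compound 2 (0.20 log units; within the scatter) changed the whole aryl group and also stayed within the scatter. Nothing measured therefore argues for a large move, and compound 4 is expected to land close to compound 3, perhaps drifting slightly toward compound 1, which is a 1.5-fold lower number from compound 3 to compound 4 (0.18 log units; within the scatter). The estimate for compound 4 in this assay is 22000 nM, with a range from 9000 nM to 50000 nM.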

Compound 4, half-maximal inhibitory concentration: 7530 nM
Compound 4: middle estimate off by 2.9-fold (0.47 log units), on the high side, and the stated range ends above it.
By their numbers in this assay, from the lowest: compounds 4, 2, 1 and 3 (each within the scatter of the next, the first and the last beyond it).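

For the compounds shown here, at the aromatic carbon para to a large group, the earlier compounds showed only a swap that stayed within the scatter, but in this assay chloro stands apart from both other groups at this place, with a 4.4-fold lower number from compound 3 to compound 4 (0.65 log units; beyond the scatter) and with a 2.2-fold lower number from compound 1 to compound 4 (0.34 log units; beyond the scatter) as well. Methyl and chloro match in their counts of heavy atoms, hydrogen-bond donors and acceptors, yet this one exchange moves the number beyond the scatter, while the 4-chlorophenyl and 2-methylphenyl groups are not told apart, with a 1.4-fold lower number from compound 2 to compound 4 (0.14 log units; within the scatter) as their step. No measurement shown here accounts for the gap between chloro and methyl.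

As far as these compounds go, how a methoxy group, an amine or a carboxylic acid would read at this same aromatic carbon remains open. So does whether fluoro or bromo would follow chloro there.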